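This account rests on a few compounds, and the source may have more. Where it says the series, first, only, none or still open, it means among the compounds named here.

Working notes on the series.

Among the measured compounds shown here, compound 2 `COc1ccc2c(c1)OC(N)=C(C#N)C2c1ccccc1` gives 360000000 nM in a functional assay on T47D cells (Homo sapiens) for activation (on this read-out lower numbers stand for an effect already at smaller amounts and higher numbers for an effect only at larger amounts of compound), the highest of the two numbers measured so far; the only other measured compound, compound 1 `COc1ccc2c(c1)OC(N)=C(C#N)C2c1cccc([N+](=O)[O-])c1`, gives 88900000 nM. For the measured compounds named here, the one step measured between them, a 4.0-fold higher number from compound 1 to compound 2 (0.61 log units; beyond the scatter), is the sole reference for this position on the ring.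

Compound 3 `COc1ccc2c(c1)OC(N)=C(C#N)C2c1cccc(Br)c1` is not yet measured. It differs from compound 2 by bromo in place of hydrogen on an aromatic carbon, on the same aromatic carbon where compound 1 carries its nitro group. The step of a 4.0-fold higher number from compound 1 to compound 2 (0.61 log units; beyond the scatter) shows that a substituent at that carbon can move the number modestly, yet bromo is a different group from nitro, so the direction for compound 3 is only loosely anchored.

Going by the values given here, a modest move toward a lower number is expected for compound 3, a 2.0-fold lower number from compound 2 to compound 3 (0.30 log units; within the scatter), because a 4.0-fold higher number from compound 1 to compound 2 (0.61 log units; beyond the scatter) is the one measured change at that carbon, though a step within the scatter is also plausible. The expected value for compound 3 is 180000000 nM, estimated between 60000000 nM and 450000000 nM.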

Compound 3, half-maximal effective concentration: 52000000 nM
The estimate for compound 3 lay 3.5-fold (0.54 log units) above the measured number, and the stated range ends above it.
By their numbers in this assay, from the lowest: compounds 3 and 1 (each within the scatter of the next); then compound 2.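

In this assay, bromo in place of hydrogen gives a 6.9-fold lower number from compound 2 to compound 3 (0.84 log units; beyond the scatter), so the move away from the number of the unsubstituted phenyl at this carbon is no longer tied to nitro alone. The exchange of the two substituents gives a 1.7-fold lower number from compound 1 to compound 3 (0.23 log units; within the scatter), which leaves bromo and nitro indistinguishable on this read-out, with compound 2 alone standing apart from both. No available data offer an account of this result.

On these data alone, two substituents at one carbon do not establish a general trend, and it remains open whether an amine, a carboxylic acid or a longer alkyl chain at this carbon would also give a lower number than hydrogen. Also open, as far as these compounds go, is whether bromo on another carbon of the phenyl would give a comparable step.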